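The compounds below may be only part of what the source reports. "The series", "measured", "known", "first", "only" and "open" are said of these compounds alone.

Compound 1 `COc1ccc(C(=O)/C=C/c2cc(-c3cc(OC)c(OC)c(OC)c3)n[nH]2)cc1OC` and compound 2 `COc1ccc(C(=O)/C=C/c2cc(-c3cc(OC)c(OC)c(OC)c3)n[nH]2)cc1` differ at a single aromatic carbon. In a functional assay on SK-MEL-5 cells (Homo sapiens) for inhibition, read by sulforhodamine B assay, with a stated time of 48 h (on this read-out higher numbers stand for lower toxicity in this test and lower numbers for higher toxicity in this test), compound 1 gives 5590 nM, and compound 2 gives 6100 nM. The step of a 1.1-fold higher number from compound 1 to compound 2 (0.04 log units; within the scatter) lies within the scatter, so compound 2 stands at the higher of the two numbers only nominally, with compound 1 nearest to it. Compound 3 `COc1cc(-c2cc(/C=C/C(=O)c3ccc(F)c(F)c3)[nH]n2)cc(OC)c1OC` differs from compound 2 by 3,4-difluorophenyl in place of 4-methoxyphenyl on a carbonyl carbon. Among the compounds with values here, no measured step alters the group on the carbonyl carbon; the sole measured step, a 1.1-fold higher number from compound 1 to compound 2 (0.04 log units; within the scatter), concerns a methoxy on an aromatic carbon elsewhere and stayed within the scatter, so it bears on this change only indirectly. With nothing pointing in either direction, the expected step of a 1.1-fold higher number from compound 2 to compound 3 (0.03 log units; within the scatter) is one that stays within the scatter. Compound 3 is therefore estimated at 6500 nM in this assay, expected to lie between 2200 nM and 19000 nM.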

Compound 3, concentration lethal to 50% of the cells: 26700 nM
Compound 3: middle estimate off by 4.1-fold (0.61 log units), on the low side; the whole stated range lies below it.
By their numbers in this assay, from the lowest: compounds 1 and 2 (each within the scatter of the next); then compound 3.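

Replacing 4-methoxyphenyl with 3,4-difluorophenyl on the carbonyl carbon gives a 4.4-fold higher number from compound 2 to compound 3 (0.64 log units; beyond the scatter) in this assay and so moves the read-out toward lower toxicity in this test. Replacing 3,4-dimethoxyphenyl at the same place gives a 4.8-fold higher number from compound 1 to compound 3 (0.68 log units; beyond the scatter) and points the same way. The group on the carbonyl carbon therefore affects this read-out, whereas the step between the two methoxy-bearing compounds stayed within the scatter.

The compounds shown leave open whether the shift follows from losing the methoxy groups or from gaining the fluorines, since plain phenyl and 4-fluorophenyl do not appear among them. They also leave open how a group such as 4-aminophenyl or 4-carboxyphenyl would behave at this place, and nothing available explains the shift.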